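Swapping benzyl for methoxymethyl on the naphthyl ether

The compounds below may be only part of what the source reports. "The series", "measured", "known", "first", "only" and "open" are said of these compounds alone.

Compound 1, `CCOc1ccc(/C=N/NC(N)=S)c2ccccc12`, in a toxicity assay on THP-1 cells (Homo sapiens) for cytotoxicity, read by MTT assay, with a stated time of 72 h (a higher number here means that more compound is needed for the effect, a lower number that less compound is needed), gives > 200000 nM, which is a limit of the assay and not a number.
Compound 2, `CCCCOc1ccc(/C=N/NC(N)=S)c2ccccc12`, in this assay gives > 200000 nM, again a limit and not a number.
Compound 3, `NC(=S)N/N=C/c1ccc(OCc2ccccc2)c2ccccc12`, in this assay gives 27000 nM.

Compound 3 is thus the only one of the three with a measured number; the other two sit at the limit of > 200000 nM in this assay, at which 2 of the 3 values shown sit. Compound 4, `COCOc1ccc(/C=N/NC(N)=S)c2ccccc12`, differs from compound 3 by methoxy in place of phenyl on a saturated chain carbon bound to an oxygen on an aromatic ring. Going by the values given here, the steps that bear on this change run the other way: an at least 7.4-fold lower number from compound 1 to compound 3 (0.86 log units; beyond the scatter) and an at least 7.4-fold lower number from compound 2 to compound 3 (0.86 log units; beyond the scatter), where a small alkyl group on that carbon gave way to phenyl. Removing the phenyl again, in favour of methoxy, is therefore expected to raise the number, likely back towards the limit, and the estimated step is a 5.6-fold higher number from compound 3 to compound 4 (0.74 log units; beyond the scatter). Compound 4 is expected to give about 150000 nM in this assay, within a range from 40000 nM to 250000 nM, with a fair chance that only a limit is reported.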

Compound 4, half-maximal effective concentration: > 200000 nM
Compound 4: a limit, no number; the forecaster's own chance of this, stated with the estimate: 55%; at least 1.3-fold (0.12 log units) between middle value and limit.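

The change from benzyloxy to methoxymethoxy gives an at least 7.4-fold higher number from compound 3 to compound 4 (0.86 log units; beyond the scatter) in this assay, which extends the earlier finding: not only ethyl and butyl chains on the oxygen, but also a chain carrying methoxy, lacks the measured effect seen with phenyl on this carbon. Compound 1, compound 2 and compound 4 all rest on the same limit of the assay, and none of them gives a number: the limit of > 200000 nM in this assay, at which 3 of the 4 values shown sit. The steps among these three compounds cannot be read, so methoxy cannot be ranked against methyl or propyl at this position.

Going by these compounds, it remains open whether any ring on this carbon would serve or only an aromatic one, which cyclohexyl or a pyridine ring in place of phenyl would address. Also open, on these data alone, is how a chlorine or a methoxy group on the phenyl ring of compound 3 would shift its number.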